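The compounds below may be only part of what the source reports. "The series", "measured", "known", "first", "only" and "open" are said of these compounds alone.

The measured compounds:
Compound 1, `Oc1cccc2cc(-c3ccccc3)ccc12`: 20%
Compound 2, `COc1ccncc1-c1ccc2c(O)cccc2c1`: < 10%

Both were tested in an assay for binding affinity to 17-beta-hydroxysteroid dehydrogenase type 2 (Homo sapiens), with a stated time of 20 min, tested at 1 uM; a higher number here means more inhibition at the concentration tested (going by the name of the read-out), a lower number less inhibition. Among the measured compounds shown here, compound 1 gives 20% in this assay, and it is the only compound here with a plain number. For compound 2 the reading in this assay is < 10%, which is a limit of the assay rather than a number. The picture thus rests on (the limit of < 10% in this assay, at which 1 of the 2 values shown sits), leaving compound 1 as the single firm point of reference, and its structure is the shared core that the next compound carries as well.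

Compound 3, `CNC(=O)c1ccc(-c2ccc3c(O)cccc3c2)cc1`, has not yet been measured in this assay. It differs from compound 1 in one place: methylcarbamoyl in place of hydrogen on an aromatic carbon. For the measured compounds named here, no measured pair shows what such a change does in this assay, so no size of step can be read off from the data. The expectation is a change no larger than the usual scatter, with a slight lean upward; the estimated step is a number 5 percentage points higher from compound 1 to compound 3 (within the scatter). Compound 3 is therefore expected to give around 25%, within 5% to 50%, with a fair chance that only a limit is reported.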

Compound 3, a percentage reported as inhibition, at one concentration (the size of the read-out at that concentration, not a potency): 13%
Compound 3: the middle estimate sits 12 percentage points above what was measured; the range from low to high includes it.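

Among the compounds shown here, putting methylcarbamoyl in place of hydrogen on an aromatic carbon, para to a large group, gives the first readable step at this position in this assay: a number 7 percentage points lower from compound 1 to compound 3 (within the scatter). Compound 1 and compound 3 therefore cannot be told apart in this measurement, so this sizeable addition to the shared core brings no clear gain or loss of inhibition at the concentration tested, though a single pair cannot show that the position accepts other groups equally well. Compound 2 gives only a limit of the assay and not a number, and it supplies no step to set beside this one: the limit of < 10% in this assay, at which 1 of the 3 values shown sits.

A single step leaves open whether a different group at this position, such as an amine, a carboxylic acid or a longer carbon chain, would move the reading beyond the usual scatter of repeated measurements. It also leaves open whether replacing the amide hydrogen, for example with a second methyl group, would change the result, and whether any such change would appear as a real potency rather than a reading at one concentration.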